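The compounds below may be only part of what the source reports. "The series", "measured", "known", "first", "only" and "open" are said of these compounds alone.

Compound 1 `CC(C)NC(=O)/C=C/c1ccccc1` gives 39% in a functional assay on the whole organism for inhibition, with Brassica rapa subsp. chinensis as the target, with a stated time of 3 days, tested at 100 ppm; a higher number here means more inhibition of growth at the concentration tested, a lower number less inhibition of growth. Compound 2 `CCC(C)NC(=O)/C=C/c1ccccc1` differs from it by methyl in place of hydrogen on a saturated chain carbon, two bonds along the chain from an amide-type nitrogen, and this change brings a number 17 percentage points higher from compound 1 to compound 2 (beyond the scatter). In this assay compound 2 gives 56%. Compound 3 `CCCOC(=O)/C=C/c1ccccc1` carries a different core, the difference being (propoxy in place of isopropylamino on a carbonyl carbon); in this assay compound 3 gives 31%. That difference amounts to a number 8 percentage points lower from compound 1 to compound 3 (within the scatter), while against compound 2 it reads a number 25 percentage points lower from compound 2 to compound 3 (beyond the scatter). Compound 3 thus stands lowest of the three numbers, though its gap to compound 1 is within the scatter and only its gap to compound 2 is beyond it.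

Compound 4 `CCCCOC(=O)/C=C/c1ccccc1` has not yet been tested in this assay. It differs from compound 3 by methyl in place of hydrogen on a saturated chain carbon, three bonds along the chain from an oxygen next to a carbonyl group. Going by the values given here, this is the same kind of change as the one from compound 1 to compound 2, where a methyl also took the place of a hydrogen on a saturated chain carbon; yet the surroundings differ, since there the carbon lay two bonds along the chain from an amide-type nitrogen, whereas here it lies three bonds along the chain from an oxygen next to a carbonyl group. Among the compounds with values here, the single earlier instance rests on a different core and gave a modest rise. Within the data shown here, with only that one step to lean on, and the core changed, compound 4 is expected to move a little upward, the expected step being a number 9 percentage points higher from compound 3 to compound 4 (within the scatter). Compound 4 is therefore estimated at 40%, between 24% and 58%.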

Compound 4, percent growth inhibition at one concentration: 5%
Compound 4: the middle estimate sits 35 percentage points above what was measured, and the stated range ends above it.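

In this assay the added methyl did not carry over from one core to the other: it brought a number 26 percentage points lower from compound 3 to compound 4 (beyond the scatter), against the rise seen on the amide core, and the two instances disagree in direction: the same change on two cores in this assay, a number 17 percentage points higher (beyond the scatter) from compound 1 to compound 2 and a number 26 percentage points lower (beyond the scatter) from compound 3 to compound 4, 43 percentage points apart, beyond the scatter of two such steps

Measured against the amides, the butoxy group also gives a number 51 percentage points lower from compound 2 to compound 4 (beyond the scatter) and a number 34 percentage points lower from compound 1 to compound 4 (beyond the scatter), which leaves compound 4 lowest of the four. This shows that the effect of this change cannot be assumed to transfer between these two cores, but with a single pair on each core it does not show what decides the outcome, since the pairs differ both in the core and in where the methyl sits, two bonds along the chain from an amide-type nitrogen in one and three bonds along the chain from an oxygen next to a carbonyl group in the other.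

The compounds shown leave open whether the fall continues along the ester chain or reverses with a longer chain such as pentoxy, and how a branched isopropoxy or sec-butoxy group behaves on the carbonyl carbon. Also open, going by these compounds, is how a straight butylamino group would compare, as it would set the same chain on both cores.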